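The source may hold more compounds than are shown below. What is called first, only, known or untested is meant among the compounds shown, and "the series" means these compounds.

In an ADME assay on the whole organism (plasma, strain Wistar) for pharmacokinetics, with Rattus norvegicus as the target, at a dose of 100 mg/kg by the oral route (on this read-out lower numbers stand for lower exposure and higher numbers for higher exposure at the dose given), compound 3 (`CCC(=O)NS(=O)(=O)c1ccc(-n2nc(C(F)(F)F)cc2-c2ccc(OC)c(C)c2)cc1CO`) gives 149000 ng.h/mL. Compound 1 (`NS(=O)(=O)c1ccc(-n2nc(C(F)F)cc2-c2ccc(Br)cc2)cc1CO`) gives 265000 ng.h/mL. Compound 2 (`CCC(=O)NS(=O)(=O)c1ccc(-n2nc(C(F)F)cc2-c2ccc(Br)cc2)cc1CO`) gives 321000 ng.h/mL. The gap between compound 3 and compound 1 lies within the scatter, while the gap between compound 3 and compound 2 lies beyond it. Compound 4 (`CCC(=O)NS(=O)(=O)c1ccc(-n2nc(C(F)F)cc2-c2ccc(OC)c(C)c2)cc1CO`) turns the trifluoromethyl of compound 3 into difluoromethyl: hydrogen in place of fluoro on a saturated chain carbon bound to an aromatic carbon and two fluorine atoms. For the measured compounds named here, no measured step covers this change. The only one, a 1.2-fold higher number from compound 1 to compound 2 (0.08 log units; within the scatter), is a different change, propanoyl in place of hydrogen on a sulfonamide nitrogen, so it offers a weak guide at best. With no direct evidence, no step beyond the scatter is expected in this assay. The estimated step is a 1.1-fold higher number from compound 3 to compound 4 (0.06 log units; within the scatter). Compound 4 is expected at 170000 ng.h/mL, with an estimated range from 85000 ng.h/mL to 340000 ng.h/mL.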

Compound 4, area under the concentration-time curve: 114000 ng.h/mL
Estimate against measurement, compound 4: 1.5-fold (0.17 log units) above, and the stated range covers the measured number.
By their numbers in this assay, from the lowest: compounds 4, 3, 1 and 2 (each within the scatter of the next, the first and the last beyond it).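

Going from trifluoromethyl to difluoromethyl gives a 1.3-fold lower number from compound 3 to compound 4 (0.12 log units; within the scatter) in this assay, so this first reading of the change at this position stays within the scatter. The aryl exchange gives a 2.8-fold lower number from compound 2 to compound 4 (0.45 log units; beyond the scatter), the first one-place step shown to lie beyond the scatter, and it points to the 4-bromophenyl site rather than the fluorine count as the place where exposure differs. Nothing shown explains either step. The fluorine change is shown only alongside 4-methoxy-3-methylphenyl, so its effect alongside 4-bromophenyl remains open. On these data alone, how a nitrile or a carboxylic acid would behave in place of difluoromethyl also remains open.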